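This account rests on a few compounds, and the source may have more. Where it says the series, first, only, none or still open, it means among the compounds named here.

Measured so far in a physicochemical assay for lipophilicity, at pH 7.4; on this read-out lower numbers stand for lower lipophilicity and higher numbers for higher lipophilicity
Compound 1 `CCOc1cc(Cl)c(C(=O)NC(=O)Nc2nc3ccc(S(=O)(=O)C4CCN(C)CC4)cc3s2)cc1-n1cccn1` gives 3 here
Compound 2 `CN1CCC(S(=O)(=O)c2ccc3nc(NC(=O)NC(=O)c4cc(-n5cccn5)c(F)cc4Cl)sc3c2)CC1` gives 2.4 here
Compound 3 `CN1CCC(S(=O)(=O)c2ccc3nc(NC(=O)NC(=O)c4cc(-n5cccn5)ccc4Cl)sc3c2)CC1` gives 2.3 here

Compound 1 stands highest of these three. Fluoro in place of its ethoxy gives a number 0.60 log units lower from compound 1 to compound 2 (beyond the scatter) and hydrogen in place of that ethoxy gives a number 0.70 log units lower from compound 1 to compound 3 (beyond the scatter) here. The remaining step is a number 0.10 log units lower from compound 2 to compound 3 (within the scatter) here.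

Compound 4 `CCOc1cc(Cl)c(C(=O)NC(=O)Nc2nc3ccc(CN4CCN(C)CC4)cc3s2)cc1-n1cccn1` keeps the ethoxy and differs elsewhere: (4-methylpiperazin-1-yl)methyl in place of (1-methylpiperidin-4-yl)sulfonyl on an aromatic carbon here. Among the measured compounds shown here, no measured step touches this place, so those steps offer only a rough yardstick of size, and the direction stays open. No step beyond the scatter is expected. The estimated step is a number 0.20 log units higher from compound 1 to compound 4 (within the scatter) with a wide margin. Compound 4 is expected at 3.2 with an estimated range from 2.6 to 3.8 here.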

Compound 4, distribution coefficient: 3.8
Compound 4: the middle estimate sits 0.60 log units below what was measured; measured number inside the range.
By their numbers in this assay, from the lowest: compounds 3 and 2 (each within the scatter of the next); then compound 1; then compound 4.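

Among the compounds shown here, this is the first measured change at this place on the core, and in this assay putting (4-methylpiperazin-1-yl)methyl in place of (1-methylpiperidin-4-yl)sulfonyl gives a number 0.80 log units higher from compound 1 to compound 4 (beyond the scatter). The read-out therefore responds here about as strongly as it did to the ethoxy changes, but upward rather than downward. Nothing available explains this rise.

The two groups differ in both ring and linkage, and the compounds shown do not separate these. From the compounds shown here alone, whether a morpholin-4-ylmethyl group here would give a similar number remains open.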